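A few compounds are considered here, and "the series" means these few. Any claim that something is new, unique, unknown or untested is made for them only; others in the source may bear on it.

Series notes, cytotoxicity on the shared core.

Compound 1 `COc1cc2c(Oc3ccc(NC(=O)c4nn(-c5ccccc5)c(=O)c5ccccc45)cc3F)ccnc2cc1OCCCN1CCN(C)CC1` and compound 2 `COc1cc2c(Oc3ccc(NC(=O)c4nn(-c5ccc(F)cc5)c(=O)c5ccccc45)cc3F)ccnc2cc1OCCCN1CCN(C)CC1` carry the same amide-linked core and differ only at one aromatic carbon of the phenyl on the ring nitrogen. In a functional assay on HT-29 cells (Homo sapiens) for cytotoxicity, read by MTT assay, with a stated time of 72 h (on this read-out lower numbers stand for stronger inhibition and higher numbers for weaker inhibition), compound 1 gives 1140 nM and compound 2 gives 320 nM. Among the compounds with values here, the single measured step, fluoro in place of hydrogen on an aromatic carbon, reads a 3.6-fold lower number from compound 1 to compound 2 (0.55 log units; beyond the scatter). Within the data shown here, compound 2 therefore stands at the lowest of the two numbers, with compound 1 as its only neighbour.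

Compound 3 `COc1cc2c(Oc3ccc(NC(=O)c4nn(-c5ccc(Br)cc5)c(=O)c5ccccc45)cc3F)ccnc2cc1OCCCN1CCN(C)CC1` continues from compound 2 by one change: bromo in place of fluoro on an aromatic carbon. Among the measured compounds shown here, no measured step in the set exchanges one halogen for another; the only step that bears on this place is the one from compound 1 to compound 2, which shows that a halogen at this aromatic carbon is tolerated and lowered the number. Exchanging fluoro for bromo at the same carbon is not expected to move the number beyond the scatter; the expected step is a 1.1-fold lower number from compound 2 to compound 3 (0.06 log units; within the scatter). For compound 3 in this assay the estimate is 280 nM, with a range of 90 nM to 900 nM.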

Compound 3, half-maximal inhibitory concentration: 850 nM
For compound 3 the middle estimate is 3.0-fold (0.48 log units) below the measured one; the measured number falls inside the stated range.
By their numbers in this assay, from the lowest: compound 2; then compounds 3 and 1 (each within the scatter of the next).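

In this assay the two halogens on this aromatic carbon, para to a large group, are not interchangeable: bromo in place of fluoro gives a 2.7-fold higher number from compound 2 to compound 3 (0.42 log units; beyond the scatter) and so does not keep the number seen with 4-fluorophenyl. Bromo in place of hydrogen gives a 1.3-fold lower number from compound 1 to compound 3 (0.13 log units; within the scatter) and thus puts compound 3 within the scatter of compound 1, so that, of the two halogens shown here, only fluoro has a step from hydrogen beyond the scatter, and compound 3 goes against any reading that a halogen at this carbon is enough to lower the number. Nothing available on these compounds accounts for the difference between fluoro and bromo at this carbon.

The compounds shown leave open whether chloro on this carbon would fall with fluoro or with bromo, and how groups of another kind, such as methoxy, nitrile or an amine, would read here. They also leave open whether the step from fluoro to bromo would hold on another carbon of the same phenyl ring.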